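Adding methyl to the phenyl of compound 2

This account rests on a few compounds, and the source may have more. Where it says the series, first, only, none or still open, it means among the compounds named here.

Measured so far:
- compound 1 `COc1ccc(-n2cnc3cnc(-c4cccc(NC(C)=O)c4)cc32)cc1OC`: 146000 nM
- compound 2 `COc1ccc(-n2cnc3cnc(-c4ccccc4)cc32)cc1OC`: 28000 nM

In a physicochemical assay for solubility (a lower number here means a less soluble compound, a higher number a more soluble compound), compound 2 stands at 28000 nM, the lower of the two numbers, and the nearest value is that of compound 1 at 146000 nM.

The next compound is compound 3 `COc1ccc(-n2cnc3cnc(-c4ccccc4C)cc32)cc1OC`, which takes phenyl to 2-methylphenyl: methyl in place of hydrogen on an aromatic carbon. This is methyl in place of hydrogen on an aromatic carbon, ortho to a large group.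

For the measured compounds named here, only one measured step bears on this change: a 5.2-fold lower number from compound 1 to compound 2 (0.72 log units; beyond the scatter). That step exchanged acetamido for hydrogen, so it sets only a loose scale for a methyl change. No measured pair in the series involves methyl, and the direction of the change is not shown by the data.

A smaller move than that step is therefore expected, most likely none beyond the scatter. The expected move is a 1.1-fold higher number from compound 2 to compound 3 (0.03 log units; within the scatter). In this assay the estimate for compound 3 is 30000 nM, with an expected range from 12000 nM to 75000 nM.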

Compound 3, solubility: > 200000 nM
Compound 3: no number, only a limit (the forecaster's own chance of this, stated with the estimate: 3%); middle value at least 6.6-fold (0.82 log units) from the limit.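

In this assay, methyl in place of hydrogen on an aromatic carbon, ortho to a large group, gives an at least 7.1-fold higher number from compound 2 to compound 3 (0.85 log units; beyond the scatter). Before this, the only step in the series was a 5.2-fold lower number from compound 1 to compound 2 (0.72 log units; beyond the scatter), which removed acetamido; compound 3 shows that a higher number on this phenyl does not depend on acetamido, since methyl, with 0 hydrogen-bond donors and 0 hydrogen-bond acceptors, goes with a step beyond the scatter too. Compound 3 gives > 200000 nM, which is a limit of the assay and not a number, so the step has a lower bound but no full size: the limit of > 200000 nM in this assay, at which 1 of the 3 values shown sits.

Still open is whether this step belongs to methyl as such or to its place ortho to a large group, as the compounds shown carry methyl at no other place on the phenyl. Also open, from the compounds shown here alone, is how an ethyl, a methoxy or a chlorine at the same place would read in this assay, and whether any such group would give a number rather than a limit.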